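A few compounds are considered here, and "the series" means these few. Any claim that something is new, unique, unknown or untested is made for them only; others in the source may bear on it.

In a functional assay on isolated protein for agonist activity at Glucose-dependent insulinotropic receptor (Homo sapiens), read by HTRF and cAMP accumulation (a higher number here means that more compound is needed for the effect, a lower number that less compound is needed), three measured compounds share one core and all three sit close together. Compound 1 `CC(C)(C)OC(=O)N1CCC(O[C@H]2CC[C@H](Oc3ccc(C#N)cc3)CC2)CC1` gives 8.6 nM. Compound 2 `CC(C)OC(=O)N1CCC(O[C@H]2CC[C@H](Oc3ccc(S(C)(=O)=O)nc3)CC2)CC1` gives 13 nM, and compound 3 `CC(C)OC(=O)N1CCC(O[C@H]2CC[C@H](Oc3cnc(S(C)(=O)=O)cn3)CC2)CC1` gives 13.7 nM. Compound 3 holds the highest of the three numbers, yet its gap to compound 2 and its gap to compound 1 both lie within the usual scatter of this assay, so the three cannot be ranked against each other.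

Compound 4 `CC(C)c1noc(CN2CCC(O[C@H]3CC[C@H](Oc4cnc(S(C)(=O)=O)cn4)CC3)CC2)n1` differs from compound 3 in one place: (3-isopropyl-1,2,4-oxadiazol-5-yl)methyl in place of isopropoxycarbonyl on an amine nitrogen in a ring. Among the compounds with values here, the only measured step, a 1.1-fold higher number from compound 2 to compound 3 (0.02 log units; within the scatter), swaps one aromatic ring for another on the oxygen on a saturated carbon, far from the amine nitrogen in a ring touched here, so no measured step speaks directly to this change. What the three values do show is that this assay has so far been tolerant of changes at the periphery of the core.

Within the data shown here, with no direct precedent, the step of a 1.1-fold higher number from compound 3 to compound 4 (0.04 log units; within the scatter) is expected to be modest, in either direction, with wide uncertainty. Compound 4 is therefore estimated to give 15 nM, with a range from 4 nM to 60 nM.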

Compound 4, half-maximal effective concentration: 14 nM
Compound 4: the middle estimate sits 1.1-fold (0.03 log units) above what was measured; measured number inside the range.
By their numbers in this assay, from the lowest: compounds 1, 2, 3 and 4 (each within the scatter of the next).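

Within the data shown here, replacing isopropoxycarbonyl with (3-isopropyl-1,2,4-oxadiazol-5-yl)methyl on the amine nitrogen in a ring gives a 1.0-fold higher number from compound 3 to compound 4 (0.01 log units; within the scatter) in this assay, the first measured step at this position. In this pair, the position accepts a larger group that brings a five-membered aromatic ring and lacks the double bond outside aromatic rings that isopropoxycarbonyl carries, so that carbonyl is not needed for a value in this range. No measurement shown here explains why the two groups give such closely matched values.

The compounds shown leave open how far this tolerance extends on the amine nitrogen, for example to a benzyl group, a simple acetyl group or a free amine with only a hydrogen there, and whether a cyclopropyl group could stand in place of the isopropyl on the oxadiazole. They also leave open whether the same exchange would give a similar result with the 6-(methylsulfonyl)pyridin-3-yl group of compound 2 at the other end of the molecule.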